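Naphthalen-2-yl in place of 4-(tert-butyl)phenyl

The compounds below may be only part of what the source reports. "The series", "measured", "known", "first", "only" and "open" are said of these compounds alone.

In a functional assay on HeLa cells (Homo sapiens) for cytotoxicity, read by MTT assay, with a stated time of 48 h (a lower number here means a stronger inhibitor, a higher number a weaker inhibitor), compound 3 (`C=C(c1ccc(OC)cc1)c1cc(OC)c(OC)c(OC)c1-c1ccc(C(C)(C)C)cc1`) gives 39000 nM as the highest of three numbers, beyond the scatter of both others. Compound 2 (`C=C(c1ccc(OC)cc1)c1cc(OC)c(OC)c(OC)c1-c1ccc(F)c(F)c1`) gives 5900 nM and compound 1 (`COc1ccc(/C=C/c2cc(OC)c(OC)c(OC)c2-c2ccc3ccccc3c2)cc1`) gives 13000 nM in the same read-out. Compound 4 (`C=C(c1ccc(OC)cc1)c1cc(OC)c(OC)c(OC)c1-c1ccc2ccccc2c1`) has naphthalen-2-yl in place of 4-(tert-butyl)phenyl on an aromatic carbon. Among the compounds with values here, the one measured step at this place is a 6.6-fold higher number from compound 2 to compound 3 (0.82 log units; beyond the scatter) and ends at 4-(tert-butyl)phenyl. Compound 1 also carries naphthalen-2-yl and stands at 13000 nM on a core that differs from that of compound 4. A step to a lower number in this assay is therefore expected, of modest size. Compound 4 is estimated at 14000 nM within a range from 5000 nM to 35000 nM in this read-out. The expected change is a 2.8-fold lower number from compound 3 to compound 4 (0.44 log units; beyond the scatter) on this estimate.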

Compound 4, half-maximal inhibitory concentration: 35000 nM
Compound 4: the middle estimate sits 2.5-fold (0.40 log units) below what was measured, and the stated range covers the measured number.
By their numbers in this assay, from the lowest: compound 2; then compound 1; then compounds 4 and 3 (each within the scatter of the next).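

In this assay, naphthalen-2-yl and 4-(tert-butyl)phenyl cannot be told apart at this position, with a 1.1-fold lower number from compound 3 to compound 4 (0.05 log units; within the scatter) as the step between them. The 3,4-difluorophenyl group keeps its lead over naphthalen-2-yl, with a 5.9-fold higher number from compound 2 to compound 4 (0.77 log units; beyond the scatter) on the shared core. With naphthalen-2-yl held fixed, the change of linker also counts, with a 2.7-fold higher number from compound 1 to compound 4 (0.43 log units; beyond the scatter) on that exchange. From the compounds shown here alone, whether an amine or a carboxylic acid at this position would give a lower number than 3,4-difluorophenyl remains open, as does whether the linker step holds with other aryl groups. Nothing available explains these differences.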